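Replacing the benzyl group of compound 1: an estimate

The source may hold more compounds than are shown below. What is called first, only, known or untested is meant among the compounds shown, and "the series" means these compounds.

Measured compounds:
- compound 1 `NC(=O)c1c(NC(=O)c2ccccc2Cl)sc2c1CCN(Cc1ccccc1Cl)C2`: 2900 nM
- compound 2 `NC(=O)c1c(NC(=O)c2ccccc2F)sc2c1CCN(Cc1c(Cl)cccc1Cl)C2`: 10300 nM
- compound 3 `NC(=O)c1c(NC(=O)c2ccccc2F)sc2c1CCN(Cc1ccc(Cl)cc1Cl)C2`: 13100 nM

In a functional assay on HL-60 cells (Homo sapiens) for antiproliferative activity, with a stated time of 24 h (a lower number here means a stronger inhibitor, a higher number a weaker inhibitor), compound 1 gives the lowest of the three numbers. Compound 2 sits a 1.3-fold higher number from compound 2 to compound 3 (0.10 log units; within the scatter) away from compound 3, a step that only swaps one dichlorophenyl pattern for another on a saturated chain carbon bound to an amine nitrogen in a ring, and it stays within the scatter. Compound 1 differs from compound 2 in two places at once, so no single step can be read between them; their values simply show compound 1 lower.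

Compound 4 `COc1ccccc1NC(=S)N1CCc2c(sc(NC(=O)c3ccccc3Cl)c2C(N)=O)C1` has not been measured. It differs from compound 1 as follows: a group of 11 heavy atoms (8 carbon, 1 nitrogen, 1 oxygen, 1 sulfur; one six-membered aromatic ring of carbon only) in place of a group of 8 heavy atoms (7 carbon, 1 chlorine; one six-membered aromatic ring of carbon only), on an amine nitrogen in a ring. Among the compounds with values here, the entering group has no common name and is nothing like a swap of chlorine positions, so the one measured step bears on it only loosely: it tells that small changes on this amine nitrogen moved the number little, but nothing about a change of this size. With no closer guidance, the expectation is a number near that of compound 1, with wide uncertainty: the step of a 1.6-fold higher number from compound 1 to compound 4 (0.19 log units; within the scatter) is expected, in the direction of a somewhat higher number but not clearly beyond the scatter. Compound 4 is therefore estimated at 4500 nM, within a range from 1200 nM to 17000 nM.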

Compound 4, half-maximal inhibitory concentration: 40900 nM
Estimate against measurement, compound 4: 9.1-fold (0.96 log units) below, and the stated range ends below it.
By their numbers in this assay, from the lowest: compound 1; then compounds 2 and 3 (each within the scatter of the next); then compound 4.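

In this assay, putting the new group in place of the 2-chlorobenzyl group on the amine nitrogen in a ring gives a 14-fold higher number from compound 1 to compound 4 (1.15 log units; beyond the scatter), a large step. Within the data shown here, the only earlier step at this nitrogen, a 1.3-fold higher number from compound 2 to compound 3 (0.10 log units; within the scatter), swapped one dichlorophenyl pattern for another and stayed within the scatter, so the number here clearly can respond to the group on this nitrogen when the whole group is replaced, not merely when its chlorine atoms are rearranged. Nothing in the data shown says what lies behind this rise.

Compound 4 changes several things at once, including the atoms linking the aromatic ring to the nitrogen, the methoxy group on that ring and the sulfur of the double bond, so the compounds shown cannot assign the rise to any one of them, and steps from compound 2 or compound 3 to compound 4 cannot be read, as they differ in more than one place. Also open, going by these compounds, is how the same position would respond to a simple methyl group, a longer alkyl chain, or the matching urea with oxygen in place of sulfur.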